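A few compounds are considered here, and "the series" means these few. Any claim that something is new, unique, unknown or untested is made for them only; others in the source may bear on it.

Measured in a functional assay on K562 cells (Homo sapiens) for cytotoxicity, read by trypan blue exclusion, with a stated time of 96 h; on this read-out higher numbers stand for weaker inhibition and lower numbers for stronger inhibition:
- compound 1 `COc1ccc(NS(=O)(=O)/C=C/c2c(F)c(F)c(F)c(F)c2F)cc1N` gives 75000 nM
- compound 2 `COc1ccc(NS(=O)(=O)/C=C/c2c(OC)cc(OC)cc2OC)cc1` gives 75 nM
- compound 3 `COC(=O)C(C)Nc1cc(NS(=O)(=O)/C=C/c2c(OC)cc(OC)cc2OC)ccc1OC` gives 300 nM

Compound 3 is the second highest of these three numbers, well below compound 1 and closer to compound 2. Compound 4 `COc1cc(OC)c(/C=C/S(=O)(=O)Nc2ccc(OC)c(NC(C)(C)C(=O)O)c2)c(OC)c1` has the same atoms as compound 3, joined differently: 1-carboxy-1-methylethyl replaces 1-(methoxycarbonyl)ethyl on a nitrogen on an aromatic ring, (1-carboxy-1-methylethyl in place of 1-(methoxycarbonyl)ethyl on a nitrogen on an aromatic ring). Within the data shown here, only one measured step bears on this change: a 4.0-fold higher number from compound 2 to compound 3 (0.60 log units; beyond the scatter), a modest step that placed the side chain on the shared core. Among the measured compounds shown here, no measured compound carries a free carboxy group, so the guidance is thin. The expected change in this assay is therefore another modest rise, a 3.3-fold higher number from compound 3 to compound 4 (0.52 log units; beyond the scatter). Compound 4 is estimated at 1000 nM, within an expected range of 200 nM to 6000 nM.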

Compound 4, half-maximal inhibitory concentration: 5 nM
For compound 4 the middle estimate is 200-fold (2.30 log units) above the measured one, and the stated range ends above it.
By their numbers in this assay, from the lowest: compound 4; then compound 2; then compound 3; then compound 1.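

In this assay, the group on this nitrogen proves decisive: the same atoms joined differently give a large drop in the number (a 60-fold lower number from compound 3 to compound 4 (1.78 log units; beyond the scatter)) . The earlier side chain raised the number, yet (1-carboxy-1-methylethyl)amino in place of hydrogen on an aromatic carbon lowers it (a 15-fold lower number from compound 2 to compound 4 (1.18 log units; beyond the scatter)) , so a side chain here need not weaken inhibition. No evidence is available to explain this result.

The change swaps the ester for a carboxylic acid and also adds a second methyl on the same carbon, and the compounds shown do not separate the two. Open too, as far as these compounds go, is how 1-carboxyethyl, the acid with a single methyl, or a primary amide in place of the acid would compare.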